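Swapping the aryl group on the chalcone chain: compound 4

This account rests on a few compounds, and the source may have more. Where it says the series, first, only, none or still open, it means among the compounds named here.

Measured so far:
compound 1 `C=CCOc1cc(OC)c(C(=O)/C=C/c2ccc([N+](=O)[O-])cc2)c(OCC=C)c1`: 12600 nM
compound 2 `C=CCOc1cc(OC)c(C(=O)/C=C/c2ccncc2)c(OCC=C)c1`: 2800 nM
compound 3 `C=CCOc1cc(OC)c(C(=O)/C=C/c2ccccc2F)c(OCC=C)c1`: 16300 nM

In an ADME assay on Vero cells (Chlorocebus sabaeus) for cytotoxicity, read by MTT assay (on this read-out higher numbers stand for weaker inhibition and lower numbers for stronger inhibition), compound 3 stands highest of the three numbers; its nearest neighbour is compound 1 (a 1.3-fold higher number from compound 1 to compound 3 (0.11 log units; within the scatter)), and its furthest is compound 2 (a 5.8-fold higher number from compound 2 to compound 3 (0.77 log units; beyond the scatter)). Compound 4 `C=CCOc1cc(OC)c(C(=O)/C=C/c2ccc(C(F)(F)F)cc2)c(OCC=C)c1` differs from compound 3 in one place: 4-(trifluoromethyl)phenyl in place of 2-fluorophenyl on a double-bonded chain carbon bound to a double-bonded chain carbon. Within the data shown here, no measured step covers this exact exchange. The closest guide is the step from a 4-nitrophenyl to the 2-fluorophenyl, a 1.3-fold higher number from compound 1 to compound 3 (0.11 log units; within the scatter), which stayed within the scatter, while only the pyridin-4-yl compound moved beyond it. A phenyl-for-phenyl exchange is therefore expected to shift this assay little, if at all: a 1.2-fold lower number from compound 3 to compound 4 (0.07 log units; within the scatter). Compound 4 is estimated at 14000 nM, in a range from 7000 nM to 28000 nM.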

Compound 4, half-maximal inhibitory concentration: 7200 nM
Estimate against measurement, compound 4: 1.9-fold (0.29 log units) above; the range from low to high includes it.
By their numbers in this assay, from the lowest: compound 2; then compounds 4, 1 and 3 (each within the scatter of the next, the first and the last beyond it).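

In this assay, exchanging one substituted phenyl for another at this place can move the number beyond the scatter (a 2.3-fold lower number from compound 3 to compound 4 (0.35 log units; beyond the scatter)), which the earlier phenyl-for-phenyl step did not show. Trifluoromethyl in place of nitro on an aromatic carbon stays within the scatter (a 1.8-fold lower number from compound 1 to compound 4 (0.24 log units; within the scatter)), and the pyridin-4-yl compound still holds the lowest number (a 2.6-fold higher number from compound 2 to compound 4 (0.41 log units; beyond the scatter)). Nothing given here explains these shifts. Still open, on these data alone, is how pyridin-3-yl, or a phenyl carrying an amine or a carboxylic acid, would read at this place.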